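Working notes: from compound 2 to compound 4

The source may hold more compounds than are shown below. What is called first, only, known or untested is meant among the compounds shown, and "the series" means these compounds.

Values measured in a functional assay on GBM2 cells (Homo sapiens) for antiproliferative activity, read by WST assay, with a stated time of 72 h (a lower number here means a stronger inhibitor, a higher number a weaker inhibitor), are as follows.
- Compound 1 `O=C(Nc1ccc(Cl)c(Cl)c1)Nc1cc2ncncc2cc1OCc1ccccc1F` gives 6000 nM
- Compound 2 `O=C(Nc1cc2ncncc2cc1OCc1ccc(F)cc1)Nc1cccc2ccccc12` gives 4500 nM
- Compound 3 `O=C(Nc1ccc(C(F)(F)F)cc1)Nc1cc2ncncc2cc1OCc1cccc(Cl)c1` gives 4700 nM

Compound 2 at 4500 nM sits within the scatter of both compound 3 and compound 1, and the three values cannot be told apart.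

Compound 4 `O=C(Nc1cc2ncncc2cc1OCc1ccccc1Cl)Nc1cccc2ccccc12` is related to compound 2 by a single change 2-chlorophenyl in place of 4-fluorophenyl on a saturated chain carbon bound to an oxygen on an aromatic ring and the rest of the structure stays the same. The swap can also be read as 4-fluorobenzyl to 2-chlorobenzyl, on a saturated chain carbon bound to an oxygen on an aromatic ring.

Within the data shown here, no two measured compounds differ in one place only, and the data therefore hold no direct measure of this change. Compound 1 and compound 3 each differ from compound 2 in more than one place, yet all three values stay within the scatter of each other. On this thin basis, no step beyond the scatter is expected in this assay and neither direction is favoured. The expectation is anchored on compound 2 at 4500 nM and nothing firmer. The estimated step of a 1.1-fold lower number from compound 2 to compound 4 (0.05 log units; within the scatter) is expected to remain within the scatter. For compound 4 the estimated value is 4000 nM with an expected range of 1800 nM to 9000 nM in this measurement.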

Compound 4, half-maximal inhibitory concentration: 2900 nM
Beside the measured number, compound 4's estimate is 1.4-fold (0.14 log units) above it, and the stated range covers the measured number.
By their numbers in this assay, from the lowest: compounds 4, 2, 3 and 1 (each within the scatter of the next, the first and the last beyond it).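

This pair gives the series its first direct reading of a single change. In this assay, among these compounds, 2-chlorophenyl in place of 4-fluorophenyl on a saturated chain carbon bound to an oxygen on an aromatic ring gives a 1.6-fold lower number from compound 2 to compound 4 (0.19 log units; within the scatter), so at this position the exchange produces no step that can be told apart from repeat measurements. The two groups match in heavy-atom count and in their hydrogen-bond donor and acceptor counts, but the change alters both the identity of the halogen and its place on the phenyl ring, and a single step cannot separate the two; no measurement shown offers an explanation for the result.

Among the compounds shown here, whether the exchange would read the same with the 3,4-dichlorophenyl or 4-trifluoromethylphenyl groups of compound 1 and compound 3 remains open, as no pair isolates the change on either of those backgrounds. Also open, as far as these compounds go, is how this assay would respond to a group of another kind at this position, such as a cyclohexyl ring, a morpholine or a carboxylic acid on the phenyl ring.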